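The source may report more compounds than this note shows. Statements on the series, on what has been measured and on what is new or still open speak of the compounds shown alone.

Measured compounds:
Compound 1, `C=C1CC[C@@H]2[C@](C)(CNCc3ccc(C)cc3)[C@H](O)CC[C@@]2(C)[C@@H]1/C=C/C1=CCOC1=O`: 740 nM
Compound 2, `C=C1CC[C@@H]2[C@](C)(CNCc3nccs3)[C@H](O)CC[C@@]2(C)[C@@H]1/C=C/C1=CCOC1=O`: 700 nM

In a functional assay on BMMC cells (Mus musculus, strain C57BL/6) for inhibition, with stated times of 5 days and 48 h (a lower number here means a stronger inhibitor, a higher number a weaker inhibitor), compound 2 gives the lowest of the two numbers, though compound 1 sits within the scatter of it, as a 1.1-fold lower number from compound 1 to compound 2 (0.02 log units; within the scatter) shows. Compound 3, `C=C1CC[C@H]2[C@@](C)(CC[C@@H](O)[C@@]2(C)C(=O)NCc2ccccc2)[C@@H]1/C=C/C1=CCOC1=O`, carries a different change: benzylcarbamoyl in place of (((1,3-thiazol-2-yl)methyl)amino)methyl on a saturated ring carbon. For the measured compounds named here, the one measured step swapped only one aromatic ring for another and stayed within the scatter, so it bears little on this larger change; no measured step mirrors it. A modest weakening is therefore expected, a 1.4-fold higher number from compound 2 to compound 3 (0.15 log units; within the scatter), within wide bounds. Compound 3 is estimated at 1000 nM, range 300 nM to 3500 nM.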

Compound 3, half-maximal inhibitory concentration: 19400 nM
Compound 3: the middle estimate sits 19-fold (1.29 log units) below what was measured; the measured number lies above the stated range.
By their numbers in this assay, from the lowest: compounds 2 and 1 (each within the scatter of the next); then compound 3.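

In this assay, putting benzylcarbamoyl on this saturated ring carbon in place of the aminomethyl side chains weakens inhibition far more than the aromatic ring swap did: a 28-fold higher number from compound 2 to compound 3 (1.44 log units; beyond the scatter), and a 26-fold higher number from compound 1 to compound 3 (1.42 log units; beyond the scatter). This position therefore tolerated a change of aromatic ring on the aminomethyl chain but not this replacement of the chain. Nothing at hand explains the loss. Going by these compounds, it remains open whether a ((1,3-thiazol-2-yl)methyl)carbamoyl group would match benzylcarbamoyl, and whether a tertiary amine or a carboxylic acid on this carbon would keep the number of compound 2.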